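A few compounds are considered here, and "the series" means these few. Any claim that something is new, unique, unknown or untested is made for them only; others in the source may bear on it.

Within the data shown here, compound 1 `Cc1cc(O)cc(C)c1-c1cccc(COc2ccc(OCC(=O)O)c(F)c2)c1` is the only member of the series with a number in a physicochemical assay for lipophilicity, using the shake flask method, in phosphate buffer, measured as octanol-water partition, with a stated time of 24 h, at pH 7.4, tested at 100 uM (on this read-out higher numbers stand for higher lipophilicity and lower numbers for lower lipophilicity), where compound 1 gives 2.37. Compound 2 `Cc1cc(OCCCS(C)(=O)=O)cc(C)c1-c1cccc(COc2ccc(N(CC(=O)O)C(=O)c3ccccc3)cc2)c1` carries no result in this assay: for compound 2 the outcome reads "not determined" (no result reported). Compound 3 `COCCOc1cc(C)c(-c2cccc(COc3ccc(OCC(=O)O)c(F)c3)c2)c(C)c1` is still unmeasured. It differs from compound 1 by 2-methoxyethyl in place of hydrogen on an oxygen on an aromatic ring. Among the measured compounds shown here, no pair of measured compounds shows a comparable move, so the size of the step rests on the change alone. A step upward beyond the usual scatter is expected, a number 0.53 log units higher from compound 1 to compound 3 (beyond the scatter). For compound 3 the estimate in this assay is 2.9, with a range from 2.5 to 3.3.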

Compound 3, distribution coefficient: 3.15
Estimate against measurement, compound 3: 0.25 log units below, within the range that was stated.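

In this assay, among these compounds, the move from hydroxy to 2-methoxyethoxy on the aromatic ring gives a number 0.78 log units higher from compound 1 to compound 3 (beyond the scatter) as the first measured step at this position. The read-out therefore responds to a change at this oxygen, and here it moves upward. Nothing available bears on the reason for this step. As far as these compounds go, it remains open whether an amine or a longer alkyl chain on the same oxygen would move the number further or reverse it. A single pair also cannot show whether this step holds elsewhere in the series.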